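Chloro in Place of Hydrogen on Two Related Cores

The source may report more compounds than this note shows. Statements on the series, on what has been measured and on what is new or still open speak of the compounds shown alone.

Compound 1 `COc1c(/C=C2/C(=O)Nc3ccccc32)c2ccccc2n1-c1ccccc1` gives 8510 nM
Compound 2 `O=C1Nc2ccccc2/C1=C\c1c(Cl)n(CCCc2ccccc2)c2ccccc12` gives 75900 nM
Compound 3 `COc1c(/C=C2/C(=O)Nc3ccc(Cl)cc32)c2ccccc2n1-c1ccccc1` gives 19100 nM

All three were tested in a functional assay on cells (Cancer cell lines, Homo sapiens) for cytotoxicity, with a stated time of 48 h; a higher number here means a weaker inhibitor of growth, a lower number a stronger inhibitor of growth. Compound 1 and compound 3 share one core, and compound 3 differs by chloro in place of hydrogen on an aromatic carbon, which gave a 2.2-fold higher number from compound 1 to compound 3 (0.35 log units; beyond the scatter). Compound 2 rests on a different core; the difference between the two cores is not broken down here. Of the three, compound 2 gives the highest number in this assay.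

Compound 4 `O=C1Nc2ccc(Cl)cc2/C1=C\c1c(Cl)n(CCCc2ccccc2)c2ccccc12` has not yet been measured. It differs from compound 2 by chloro in place of hydrogen on an aromatic carbon, the same change seen from compound 1 to compound 3. In this assay, for the measured compounds named here, the expected step is a 2.1-fold higher number from compound 2 to compound 4 (0.32 log units; beyond the scatter), beside the earlier 2.2-fold higher number from compound 1 to compound 3 (0.35 log units; beyond the scatter), because a 2.2-fold higher number from compound 1 to compound 3 (0.35 log units; beyond the scatter) is the only guide available. Compound 4 is therefore estimated at 160000 nM, likely between 60000 nM and 400000 nM.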

Compound 4, concentration for total growth inhibition: 10200 nM
Compound 4: the middle estimate sits 16-fold (1.20 log units) above what was measured; measured number outside the range, below it.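

In this assay, chloro in place of hydrogen on an aromatic carbon gave a 7.4-fold lower number from compound 2 to compound 4 (0.87 log units; beyond the scatter), so on this core the change moves the number the opposite way from the earlier step. The change therefore does not carry over from one core to the other, in direction or in size: the same change on two cores in this assay, a 2.2-fold higher number (0.35 log units; beyond the scatter) from compound 1 to compound 3 and a 7.4-fold lower number (0.87 log units; beyond the scatter) from compound 2 to compound 4, 17-fold (1.22 log units) apart, beyond the scatter of two such steps. This does not show which part of the cores is responsible, as they differ in more than one place, and two pairs cannot predict the change on a further core.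

On these data alone, it remains open whether another group in the same place, such as fluoro or an amine, would also behave differently on the two cores.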